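Replacing the amide nitrogen's hydrogen by a ring closure

This account rests on a few compounds, and the source may have more. Where it says the series, first, only, none or still open, it means among the compounds named here.

Measured compounds:
compound 1, `CCCNC(=O)CC1CCc2cc(OC)c(OC)cc21`, 26.9%
compound 2, `COc1cc2c(cc1OC)C(CC(=O)NC1CCCCC1)CC2`, 44.7%

Both were tested in a functional assay on the whole organism (strain Swiss albino) for inhibition, with Mus musculus as the target, in the writhing test, with stated times of 60 min and 15 min, at a dose of 100 mg/kg by the oral route; a higher number here means more inhibition at the dose given (going by the name of the read-out), a lower number less inhibition. Compound 1 gives 26.9%, while compound 2 gives 44.7%, the higher of the two numbers. Among the measured compounds shown here, the one measured step, a number 17.8 percentage points higher from compound 1 to compound 2 (beyond the scatter), comes from putting cyclohexyl in place of propyl on an amide-type nitrogen.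

Compound 3, `COc1cc2c(cc1OC)C(CC(=O)N1CCCCC1)CC2`, differs from compound 2 at the carbonyl carbon: piperidin-1-yl in place of cyclohexylamino on a carbonyl carbon. The nitrogen that carried a hydrogen in compound 2 is now part of the entering piperidin-1-yl group, so the hydrogen-bond donor is gone. For the measured compounds named here, the only measured step concerns a different change, the group attached to that nitrogen, and so it does not show what removing the hydrogen does. Going by the values given here, with no directly comparable step, no change beyond the scatter can be predicted with confidence, and the expected step of a number 4.7 percentage points lower from compound 2 to compound 3 (within the scatter) is set near zero with a wide spread. Compound 3 is therefore estimated at 40% in this assay, within the range 25% to 55%.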

Compound 3, a percentage reported as inhibition, in the whole organism at one dose (the size of the read-out at that dose, not a potency): 44.7%
Estimate against measurement, compound 3: 4.7 percentage points below, within the range that was stated.
By their numbers in this assay, from the lowest: compound 1; then compounds 2 and 3 (each within the scatter of the next).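

In this assay, the amide hydrogen turns out not to be required for inhibition at this dose, at least in this pair: closing the nitrogen into a ring gives no change at the digits printed from compound 2 to compound 3 (within the scatter) even though the hydrogen-bond donor counted for cyclohexylamino is gone. The ring-closed amide also keeps the advantage over the open propyl chain, with a number 17.8 percentage points higher from compound 1 to compound 3 (beyond the scatter) when piperidin-1-yl replaces propylamino on a carbonyl carbon, so both compounds carrying a six-membered ring stand beyond the scatter from compound 1 and within the scatter of each other. Nothing available here offers a measured explanation for why the change on the nitrogen leaves the number as it is.

Going by these compounds, what remains open is whether the ring itself matters or only the amount of carbon around the nitrogen, a question that dipropylamino, an open-chain group on the same carbonyl carbon, or pyrrolidin-1-yl, a smaller ring, could help answer. Morpholin-4-yl would extend the question to a second hetero atom in the ring, and since each number comes from a single dose, the compounds' relative potency also stays unknown.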